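The compounds below may be only part of what the source reports. "The series", "measured", "known", "first", "only" and "open" are said of these compounds alone.

Measured in an ADME assay on microsomes from liver (Homo sapiens) for pharmacokinetics, read by LC-MS, with a stated time of 60 min, tested at 1 uM; a higher number here means faster removal of the compound, a lower number slower removal:
compound 1 `O=C(NCc1ccc(S(=O)(=O)c2cncc(C(F)(F)F)c2)cc1)N1Cc2ccncc2C1`: 13 mL/min/kg
compound 2 `O=C(NCc1ccc(S(=O)(=O)c2cc(F)cc(F)c2)cc1)N1Cc2ccncc2C1`: 8 mL/min/kg
compound 3 `O=C(NCc1ccc(S(=O)(=O)C2CCC(F)(F)CC2)cc1)N1Cc2ccncc2C1`: 6 mL/min/kg

Compound 2 stands second highest of the three numbers: a 1.6-fold lower number from compound 1 to compound 2 (0.21 log units; within the scatter) and a 1.3-fold lower number from compound 2 to compound 3 (0.12 log units; within the scatter) are both within the scatter, so the three compounds are not separated with confidence, apart from a 2.2-fold lower number from compound 1 to compound 3 (0.34 log units; beyond the scatter), which is beyond the scatter and modest.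

Compound 4 `O=C(NCc1ccc(S(=O)(=O)C2CCOCC2)cc1)N1Cc2ccncc2C1` differs from compound 2 in one place: oxan-4-yl in place of 3,5-difluorophenyl on a sulfonyl sulfur. For the measured compounds named here, the step that bears most on it is the one from compound 2 to compound 3, where a six-membered non-aromatic ring also replaced the 3,5-difluorophenyl on the sulfonyl sulfur and the number moved within the scatter. On that basis the expected change in this assay is small, a 1.3-fold lower number from compound 2 to compound 4 (0.12 log units; within the scatter), and compound 4 is estimated at 6 mL/min/kg, within 3 mL/min/kg to 12 mL/min/kg.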

Compound 4, clearance: 6 mL/min/kg
Compound 4: middle estimate and measured number agree at the digits printed, and the stated range covers the measured number.
By their numbers in this assay, from the lowest: compounds 3, 4, 2 and 1 (each within the scatter of the next, the first and the last beyond it).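

On the sulfonyl sulfur, oxan-4-yl brings a ring oxygen and one hydrogen-bond acceptor, yet this assay shows no change at the digits printed from compound 3 to compound 4 (within the scatter) and so does not separate it from 4,4-difluorocyclohexyl. Against 3,5-difluorophenyl the change gives a 1.3-fold lower number from compound 2 to compound 4 (0.12 log units; within the scatter) and stays unresolved, while against 5-(trifluoromethyl)pyridin-3-yl it gives a 2.2-fold lower number from compound 1 to compound 4 (0.34 log units; beyond the scatter) and repeats the modest gap already seen with compound 3. No supporting data on the cause accompany these steps. From the compounds shown here alone, whether a basic amine such as piperidin-4-yl or a carboxylic acid on the ring would hold clearance in this range remains open.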